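This account rests on a few compounds, and the source may have more. Where it says the series, first, only, none or still open, it means among the compounds named here.

Compound 1 `COc1ccc(-c2cn3ccnc3c(-c3ccc4ncn(C5CCCCC5)c4c3)n2)cc1` gives 83.2% in a functional assay on 786-0 cells (Homo sapiens) for inhibition, read by sulforhodamine B assay, with a stated time of 48 h, tested at 10 uM; on this read-out higher numbers stand for more inhibition at the one concentration tested (going by the name of the read-out) and lower numbers for less inhibition. Compound 2 `Fc1ccccc1-c1cn2ccnc2c(-c2ccc3ncn(C4CCCCC4)c3c2)n1` gives 2.94% in this assay, the lowest of the two numbers; its nearest neighbour is compound 1, and the step of a number 80.3 percentage points lower from compound 1 to compound 2 (beyond the scatter) shows how much the aryl group at this position matters. Compound 3 `c1csc(-c2cn3ccnc3c(-c3ccc4ncn(C5CCCCC5)c4c3)n2)c1` differs from compound 2 by thiophen-2-yl in place of 2-fluorophenyl on an aromatic carbon. Among the compounds with values here, no measured step swaps in a thiophen-2-yl, so the only guide is that one large step, which makes a sizeable move in either direction plausible. A rise a number 37.1 percentage points higher from compound 2 to compound 3 (beyond the scatter) is expected, giving compound 3 an estimated 40%, within 5% to 85%.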

Compound 3, a percentage reported as inhibition, at one concentration (the size of the read-out at that concentration, not a potency): 4.1%
Compound 3: middle estimate off by 35.9 percentage points, on the high side, outside the stated range (below it).
By their numbers in this assay, from the lowest: compounds 2 and 3 (each within the scatter of the next); then compound 1.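

The 2-fluorophenyl and thiophen-2-yl groups cannot be told apart in this assay: the step is a number 1.2 percentage points higher from compound 2 to compound 3 (within the scatter). A second aryl group of a different ring size therefore also falls far short of 4-methoxyphenyl, with a number 79.1 percentage points lower from compound 1 to compound 3 (beyond the scatter), so high inhibition is not shared by all three aryl groups at this position. Nothing available here explains that gap. As far as these compounds go, it remains open whether the methoxy group itself is what matters, and how a phenyl ring carrying an amine or a carboxylic acid would read at this position.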